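HMG-CoA reductase series: amide substituent change to compound 4

The source may report more compounds than this note shows. Statements on the series, on what has been measured and on what is new or still open speak of the compounds shown alone.

Measured compounds in an assay on microsomes from liver for inhibition of 3-hydroxy-3-methylglutaryl-coenzyme A reductase (Rattus norvegicus); a lower number here means a stronger inhibitor, a higher number a weaker inhibitor:
- compound 1, `CC(C)c1c(C(=O)N2CCC[C@H](c3ccccc3)C2)nn(-c2ccc(F)cc2)c1CC[C@@H](O)C[C@@H](O)CC(=O)O`: 2.1 nM
- compound 2, `CCN(Cc1ccccc1)C(=O)c1nn(-c2ccc(F)cc2)c(OC[C@@H](O)C[C@@H](O)CC(=O)O)c1C(C)C`: 14 nM
- compound 3, `CC(C)c1c(C(=O)NCc2cccc(F)c2F)nn(-c2ccc(F)cc2)c1OC[C@@H](O)C[C@@H](O)CC(=O)O`: 2 nM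

Compound 3 gives the lowest number of the three in this assay, though compound 1 sits within the scatter of it, so no order between compound 3 and compound 1 can be read. Compound 2 stands clearly apart: the step of a 7.0-fold lower number from compound 2 to compound 3 (0.85 log units; beyond the scatter) is the only one in the set that lies beyond the scatter, and it shows that the group on the amide carbonyl can move the number by a modest amount.

Compound 4, `COCc1cccc(CNC(=O)c2nn(-c3ccc(F)cc3)c(OC[C@@H](O)C[C@@H](O)CC(=O)O)c2C(C)C)c1`, keeps the core of compound 3 and the benzylamide and alters only the aryl part: 3-(methoxymethyl)phenyl in place of 2,3-difluorophenyl on a saturated chain carbon bound to an amide-type nitrogen.

Among the measured compounds shown here, no measured pair tests a substituent change on this phenyl ring; the one informative step concerns the amine portion as a whole, not ring substituents. The step expected in this assay is therefore small, at most a mild weakening, and may well fall within the scatter. For compound 4 the estimate is 4 nM (range 1.5 nM to 12 nM), which corresponds to an expected step of a 2.0-fold higher number from compound 3 to compound 4 (0.30 log units; within the scatter).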

Compound 4, half-maximal inhibitory concentration: 31 nM
Estimate against measurement, compound 4: 7.8-fold (0.89 log units) below, and the stated range ends below it.
By their numbers in this assay, from the lowest: compounds 3 and 1 (each within the scatter of the next); then compound 2; then compound 4.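

In this assay, the aryl group on a saturated chain carbon bound to an amide-type nitrogen is not a tolerant place in this series: a 16-fold higher number from compound 3 to compound 4 (1.19 log units; beyond the scatter) is graded large, whereas a 7.0-fold lower number from compound 2 to compound 3 (0.85 log units; beyond the scatter), which replaces the whole amine portion, is graded modest. The low number of compound 3 therefore does not carry over to every secondary benzylamide, since a 2.2-fold higher number from compound 2 to compound 4 (0.35 log units; beyond the scatter) places this amide on the weaker side of the tertiary benzyl(ethyl)amino amide, even though compound 4 has the amide hydrogen that compound 2 lacks. Nothing available explains the loss at this position.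

The step from 2,3-difluorophenyl to 3-(methoxymethyl)phenyl removes both fluorines and adds the methoxymethyl group at once, so the compounds shown cannot tell whether the higher number comes from what leaves, what enters or both. A plain benzylamino group would separate these two parts, and a hydroxymethyl group in place of methoxymethyl would show whether the ether oxygen or its methyl carbon matters to the result.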